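Swapping chloro for fluoro on the benzamide ring

A few compounds are considered here, and "the series" means these few. Any claim that something is new, unique, unknown or untested is made for them only; others in the source may bear on it.

Compound 1 `NC(=O)c1c(NC(=O)c2ccccc2F)sc2c1CCN(Cc1cccc(Cl)c1)C2` gives 49500 nM in a functional assay on HeLa cells (Homo sapiens) for antiproliferative activity, with a stated time of 24 h; on this read-out lower numbers stand for stronger inhibition and higher numbers for weaker inhibition.
Compound 2 `NC(=O)c1c(NC(=O)c2ccccc2F)sc2c1CCN(Cc1c(Cl)cccc1Cl)C2` gives 33000 nM in this assay.
Compound 3 `NC(=O)c1c(NC(=O)c2ccccc2Cl)sc2c1CCN(C(=O)Nc1ccccc1Cl)C2` gives 45400 nM in this assay.

Compound 3 stands second highest of the three numbers; the gap to compound 1 and the gap to compound 2 both lie within the scatter, so the three are indistinguishable here. Compound 4 `NC(=O)c1c(NC(=O)c2ccccc2F)sc2c1CCN(C(=O)Nc1ccccc1Cl)C2` differs from compound 3 by fluoro in place of chloro on an aromatic carbon. Going by the values given here, no measured step covers this change: the only step available, a 1.5-fold lower number from compound 1 to compound 2 (0.18 log units; within the scatter), concerns a different part of the molecule and stayed within the scatter, so it tells nothing about the halogen swap. With no evidence for either direction, compound 4 is expected to sit near compound 3, a step of a 1.0-fold lower number from compound 3 to compound 4 (0.00 log units; within the scatter). The estimate for compound 4 is 45000 nM, ranging from 20000 nM to 100000 nM.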

Compound 4, half-maximal inhibitory concentration: > 50000 nM
Compound 4 was reported as a limit; the forecaster's own chance of this, stated with the estimate: 10%; middle value at least 1.1-fold (0.04 log units) away from the limit.
By their numbers in this assay, from the lowest: compounds 2, 3 and 1 (each within the scatter of the next). At a limit, above all of these: compound 4.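

Compound 4 is reported in this assay as a limit rather than a number: the limit of > 50000 nM in this assay, at which 1 of the 4 values shown sits. For fluoro in place of chloro on this aromatic carbon, the result gives an at least 1.1-fold higher number from compound 3 to compound 4 (0.04 log units; that floor lies within the scatter) and shows no clear change in either direction. For (2-chlorophenyl)carbamoyl in place of 2,6-dichlorobenzyl, it gives an at least 1.5-fold higher number from compound 2 to compound 4 (0.18 log units; that floor lies within the scatter) and for (2-chlorophenyl)carbamoyl in place of 3-chlorobenzyl, it gives a number no lower from compound 1 to compound 4 (the limit leaves the size open). As far as these compounds go, how far compound 4 lies past its limit remains open. So does whether a methoxy group or an amine on this aromatic carbon would change the number.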